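The source may report more compounds than this note shows. Statements on the series, on what has been measured and on what is new or still open speak of the compounds shown alone.

Compound 1 `O=C(/C=C/c1cn([C@@H]2C[C@@H](C(=O)O)N(Cc3ccccc3)C2)nn1)NO` gives 12% in an assay on Sf9 cells for inhibition of histone deacetylase 11 (Homo sapiens), read by fluorescence, tested at 0.5 uM; a lower number here means less inhibition, a higher number more inhibition at the concentration tested (going by the name of the read-out). Compound 2 `O=C(/C=C/c1cn([C@@H]2C[C@@H](C(=O)O)N(CCCc3ccccc3)C2)nn1)NO` gives < 10% in this assay, which is a limit of the assay and not a number. Compound 3 `O=C(/C=C/c1cn([C@@H]2C[C@H](C(=O)O)N(Cc3ccccc3)C2)nn1)NO` gives < 10% in this assay, likewise a limit of the assay.

Among the three, compound 1 holds the only number shown; the other two values are limits. The two measured steps both run away from compound 1: a number at least 2 percentage points lower from compound 1 to compound 2 (that floor lies within the scatter) and a number at least 2 percentage points lower from compound 1 to compound 3 (that floor lies within the scatter). Both are floors that lie within the scatter, so the data do not show whether either change truly lowers inhibition, given the limit of < 10% in this assay, at which 2 of the 3 values shown sit, and (the fact that compounds 1 and 3 differ only in the configuration as drawn).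

The unmeasured compound 4 `O=C(NO)c1cccc(-c2cn([C@@H]3C[C@@H](C(=O)O)N(Cc4ccccc4)C3)nn2)c1` differs from compound 1 elsewhere: 3-(hydroxycarbamoyl)phenyl in place of 2-(hydroxycarbamoyl)ethenyl on an aromatic carbon. For the measured compounds named here, neither measured step touches this position, one altering the group on the ring amine and the other only the configuration as drawn, so no measured step bears directly on the move to compound 4. Going by the values given here, with the shared core otherwise unchanged and the only number sitting low, the expected step of no change at the digits printed from compound 1 to compound 4 (within the scatter) is small and within the scatter. Compound 4 is therefore expected to give about 12% in this assay, between 4% and 24%, with a fair chance that only a limit is reported.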

Compound 4, a percentage reported as inhibition, at one concentration (the size of the read-out at that concentration, not a potency): < 10%
Compound 4: no number, only a limit; the forecaster's own chance of this, stated with the estimate: 40%; at least 2 percentage points between middle value and limit.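

The earlier compounds shown here changed only the group on the ring amine and the configuration as drawn, whereas compound 4 gives a reading for a change at the aromatic carbon that carries the hydroxycarbamoyl side chain: in this assay, 3-(hydroxycarbamoyl)phenyl in place of 2-(hydroxycarbamoyl)ethenyl gives a number at least 2 percentage points lower from compound 1 to compound 4 (that floor lies within the scatter). Compound 4 gives < 10%, which is a limit of the assay and not a number. The exchange therefore brings no gain in inhibition at this position, but it cannot be read as a true loss either, because the step is only a floor and the values now crowd at the bottom of the range: the limit of < 10% in this assay, at which 3 of the 4 values shown sit.

The compounds shown leave open whether any group at this position can lift inhibition clear of that limit, for example a longer saturated chain ending in the hydroxycarbamoyl group. They also leave open whether an ester or an amide in place of the carboxylic acid on the shared core would change the read-out in this assay.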